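Trimethoxyphenyl on the Carbonyl Side of a Pyrazole Enone

This account rests on a few compounds, and the source may have more. Where it says the series, first, only, none or still open, it means among the compounds named here.

Of the compounds shown here, three sharing one core have been measured in a functional assay on HT-29 cells (Homo sapiens) for cytotoxicity, read by sulforhodamine B assay, with a stated time of 48 h, tested at 10 uM; a lower number here means a stronger effect, a higher number a weaker effect of the compound at the concentration tested. Compound 1 `COc1cc(-c2cc(/C=C/C(=O)c3ccc(N)cc3)[nH]n2)cc(OC)c1OC` gives -38%, compound 2 `COc1ccc(C(=O)/C=C/c2cc(-c3cc(OC)c(OC)c(OC)c3)n[nH]2)cc1OC` gives -94%, and compound 3 `COc1cc(-c2cc(/C=C/C(=O)c3ccc(F)c(F)c3)[nH]n2)cc(OC)c1OC` gives -24%. Compound 2 stands lowest of the three, and both of its steps are beyond the scatter: the change of a number 56 percentage points lower from compound 1 to compound 2 (beyond the scatter) and the change of a number 70 percentage points higher from compound 2 to compound 3 (beyond the scatter) show that the aryl group on the carbonyl carbon governs the read-out in this assay, while the smaller change of a number 14 percentage points higher from compound 1 to compound 3 (beyond the scatter) points the other way for the fluorinated ring.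

Compound 4 `COc1cc(C(=O)/C=C/c2cc(-c3cc(OC)c(OC)c(OC)c3)n[nH]2)cc(OC)c1OC` differs from compound 2 by methoxy in place of hydrogen on an aromatic carbon. For the measured compounds named here, no measured step adds a methoxy group to an already dimethoxylated ring, so the two large steps around compound 2 bear on it only indirectly: they say that this ring is sensitive, but not in which direction a further methoxy moves the number. Because compound 2 already gives -94%, very little room remains downward, and the author expects a small step, a number 9 percentage points higher from compound 2 to compound 4 (within the scatter), within or near the scatter. Compound 4 is therefore estimated at -85%, with a range from -100% to -55%.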

Compound 4, a percentage reported as activity, at one concentration (the size of the read-out at that concentration, not a potency): -86%
For compound 4 the middle estimate is 1 percentage points above the measured one; measured number inside the range.
By their numbers in this assay, from the lowest: compounds 2 and 4 (each within the scatter of the next); then compound 1; then compound 3.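

In this assay, for the compounds shown here, the step of a number 8 percentage points higher from compound 2 to compound 4 (within the scatter) is the first change on the carbonyl-side ring that does not separate two compounds. The earlier steps shown here on this ring each exchanged one whole aryl group for another and all lay beyond the scatter, whereas this one places a single methoxy on an aromatic carbon, ortho to a methoxy group and meta to a large group, and compound 2 and compound 4 cannot be told apart; the ring is therefore sensitive to which aryl group stands on the carbonyl carbon, yet this added methoxy leaves the read-out within the scatter. Nothing at hand gives a reason for this outcome.

The compounds shown leave open whether this position accepts groups other than methoxy, such as a hydroxy group, an ethoxy group or a chlorine atom, as readily as it accepts methoxy. They also leave open whether the same methoxy in place of hydrogen would be as quiet on a ring that carries fewer methoxy groups, such as the 3,4-difluorophenyl ring of compound 3.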